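The compounds below may be only part of what the source reports. "The series", "measured", "known", "first", "only" and "open" are said of these compounds alone.

Measured compounds:
- compound 1, `COc1ccc(CCCc2ccc(OC)c(OC)c2)c(O)c1`: 88.9%
- compound 2, `COc1ccc(CCC(=O)c2ccc(OC)c(OC)c2)cc1O`: 91.8%
- compound 3, `COc1ccc(/C=C/C(=O)c2ccc(OC)c(OC)c2)cc1OC`: 81.3%

All three numbers come from an ADME assay on RAW264.7 cells (Mus musculus) for cytotoxicity, read by MTT assay, with a stated time of 24 h, tested at 5 ug/mL; on this read-out lower numbers stand for a stronger effect and higher numbers for a weaker effect at the one concentration tested. On these numbers compound 1 sits between compound 2 and compound 3, and the gap to each of them lies within the usual scatter of repeated measurements, so the three compounds cannot be told apart on this read-out. Among the measured compounds shown here, no pair of these measured compounds differs in only one place, so no measured step is available as a guide.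

Compound 4, `COc1ccc(CCCc2ccc(OC)cc2O)cc1`, differs from compound 1 in one place: hydrogen in place of methoxy on an aromatic carbon. For the measured compounds named here, nothing among the measured compounds shows what such a change does in this assay. With all three measured numbers clustered closely, no shift beyond the scatter is expected from this change; the step from compound 1 to compound 4 is expected to be small, a number 0.9 percentage points lower from compound 1 to compound 4 (within the scatter). Compound 4 is therefore estimated to give 88% in this assay, expected to fall between 78% and 96%.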

Compound 4, a percentage reported as activity, at one concentration (the size of the read-out at that concentration, not a potency): 94.6%
Estimate against measurement, compound 4: 6.6 percentage points below; the measured number falls inside the stated range.
By their numbers in this assay, from the lowest: compounds 3, 1, 2 and 4 (each within the scatter of the next, the first and the last beyond it).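

Among the compounds shown here, compound 4 supplies the first one-place step in this assay: hydrogen in place of methoxy on an aromatic carbon, ortho to a methoxy group and meta to a large group, gives a number 5.7 percentage points higher from compound 1 to compound 4 (within the scatter). At this position, then, the methoxy group can give way to hydrogen with no difference that can be told from the scatter of this read-out, at the one concentration tested. Nothing available explains why the two compounds read alike.

Still open, as far as these compounds go, is whether a different group at this same position, such as an amine, a carboxylic acid or a longer chain, would read the same way. The single concentration also leaves open whether compound 1 and compound 4 would stay alike at other concentrations.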